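Furoyl thioimidazolidine acrylonitriles: amide to ketone

The compounds below may be only part of what the source reports. "The series", "measured", "known", "first", "only" and "open" are said of these compounds alone.

Compound 2 `N#C/C(=C\N1CCN(C(=O)c2ccco2)C1=S)C(N)=O` gives 17600 nM in a functional assay on NCI-H322M cells (Homo sapiens) for inhibition, read by sulforhodamine B assay, with a stated time of 48 h (on this read-out lower numbers stand for stronger inhibition of growth and higher numbers for weaker inhibition of growth), and sits within the scatter of compound 1 `N#C/C(=C\N1CCN(C(=O)c2ccco2)C1=S)C(=O)Nc1ccc(Cl)cc1`, which gives 28600 nM. For the measured compounds named here, the only measured step, a 1.6-fold lower number from compound 1 to compound 2 (0.21 log units; within the scatter), concerns the amide nitrogen, not the carbonyl carbon. Going by the values given here, compound 3 `N#C/C(=C\N1CCN(C(=O)c2ccco2)C1=S)C(=O)c1ccccc1` differs by phenyl in place of amino on a carbonyl carbon; no measured step bears on that position, so a step of no size beyond the scatter is expected, a 1.1-fold higher number from compound 2 to compound 3 (0.06 log units; within the scatter). Compound 3 is therefore estimated at 20000 nM in this assay, with a range of 5000 nM to 80000 nM.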

Compound 3, concentration for 50% growth inhibition: 23400 nM
Compound 3: the middle estimate sits 1.2-fold (0.07 log units) below what was measured, and the stated range covers the measured number.
By their numbers in this assay, from the lowest: compounds 2, 3 and 1 (each within the scatter of the next).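

At the carbonyl carbon in this assay, phenyl in place of amino gives a 1.3-fold higher number from compound 2 to compound 3 (0.12 log units; within the scatter) and phenyl in place of (4-chlorophenyl)amino gives a 1.2-fold lower number from compound 1 to compound 3 (0.09 log units; within the scatter), so both steps stay within the scatter. Carbamoyl, benzoyl and the 4-chlorophenyl amide therefore cannot be told apart on this read-out, and this position no longer needs an amide nitrogen to give a number in this range. Nothing available accounts for this result. Going by these compounds, a carboxylic acid or an acetyl group on this carbon remains open, as does a substituted benzoyl. On these data alone, the furoyl group is common to all three compounds, so its contribution also remains open.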